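Two Amine Ends, Two Cores, One Untested Compound

This account rests on a few compounds, and the source may have more. Where it says the series, first, only, none or still open, it means among the compounds named here.

Compound 1 `CCN(CC)Cc1ccc(NC(=O)N/N=C(\C)c2ccccn2)cc1` carries a diethylamino group on the saturated chain carbon bound to an aromatic carbon. In a functional assay on U-937 cells (Homo sapiens) for antiproliferative activity, read by CCK-8 assay, with a stated time of 24 h (on this read-out higher numbers stand for weaker inhibition and lower numbers for stronger inhibition), compound 1 gives only a limit, > 40000 nM. Compound 2 `C/C(=N\NC(=O)Nc1ccc(CN2CCC(C)CC2)cc1)c1ccccn1` differs from it by 4-methylpiperidin-1-yl in place of diethylamino on a saturated chain carbon bound to an aromatic carbon. In this assay compound 2 likewise gives only a limit, > 40000 nM. The step that the two limits leave unreadable from compound 1 to compound 2 therefore cannot be sized because both readings sit at the limit of > 40000 nM in this assay, at which 2 of the 3 values shown sit. Compound 3 `CCN(CC)Cc1ccc(NC(=O)NN=C(c2ccccc2)c2ccccc2)cc1` is built on a different core; how that core differs from the core of compound 1 is not broken down here. In this assay compound 3 gives only a limit, > 25000 nM, the reading recorded as the limit of > 25000 nM in this assay, at which 1 of the 3 values shown sits. Compound 4 `CC1CCN(Cc2ccc(NC(=O)NN=C(c3ccccc3)c3ccccc3)cc2)CC1` has not been measured and differs from compound 3 by 4-methylpiperidin-1-yl in place of diethylamino on a saturated chain carbon bound to an aromatic carbon, the same change that separates compound 1 from compound 2, at the same place. Since the earlier step stayed unreadable at the limit, the step that the limit leaves unreadable from compound 3 to compound 4 is expected to be small. Compound 4 is accordingly estimated at 40000 nM, most likely reported once more only as a limit.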

Compound 4, half-maximal inhibitory concentration: > 25000 nM
Compound 4: no number, only a limit; the forecaster's own chance of this, stated with the estimate: 85%; the middle value does not contradict the limit.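

Compound 4, like compound 3, gives only a limit in this assay, so no step between compound 3 and compound 4 can be read: the limit of > 25000 nM in this assay, at which 2 of the 4 values shown sit.

The compounds shown leave open whether 4-methylpiperidin-1-yl in place of diethylamino changes anything in this assay on either core, and at what concentration, if any, the four compounds would inhibit these cells.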